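A Methyl on the Amide Nitrogen of Compound 2

This account rests on a few compounds, and the source may have more. Where it says the series, first, only, none or still open, it means among the compounds named here.

Three compounds on a shared core have been run in an in vitro ADME assay on microsomes from liver (Homo sapiens) for metabolic stability, tested at 1 uM; on this read-out higher numbers stand for a longer-lived compound and lower numbers for a shorter-lived compound. Compound 1 `Cc1cc(CCC#N)cc(C)c1Oc1cc(Nc2ccc(C#N)cc2)c(N)cc1C(F)(F)F` gives 0.928 h. Compound 2 `Cc1cc(CCC#N)cc(C)c1Oc1cc(Nc2ccc(C#N)cc2)c(N)cc1C(N)=O` gives 0.7 h, and compound 3 `Cc1cc(/C=C/C#N)cc(C)c1Oc1cc(Nc2ccc(C#N)cc2)c(N)cc1[N+](=O)[O-]` gives 0.797 h. Within the data shown here, compound 2 holds the lowest of the three numbers, yet both gaps fall within the scatter: the one single-change step among the measured pairs, a 1.3-fold lower number from compound 1 to compound 2 (0.12 log units; within the scatter), is within the scatter, and compound 3 stands close by.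

Compound 4 `CNC(=O)c1cc(N)c(Nc2ccc(C#N)cc2)cc1Oc1c(C)cc(CCC#N)cc1C` is next to be read in this assay. It differs from compound 2 in one place: methyl in place of hydrogen on an amide-type nitrogen. Among the measured compounds shown here, no measured step touches the amide-type nitrogen. For the measured compounds named here, the only step that bears on this part of the core, a 1.3-fold lower number from compound 1 to compound 2 (0.12 log units; within the scatter), replaced the entire group on the aromatic carbon and still stayed within the scatter, and all three measured half-lives sit close together. A methyl entering on the amide-type nitrogen is therefore expected to shift the half-life by no more than the scatter, in no set direction. Compound 4 is estimated at 0.75 h, with a range from 0.4 h to 1.4 h. The step of a 1.1-fold higher number from compound 2 to compound 4 (0.03 log units; within the scatter) that this estimate implies is expected to lie within the scatter.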

Compound 4, half-life: 0.928 h
Beside the measured number, compound 4's estimate is 1.2-fold (0.09 log units) below it; measured number inside the range.
By their numbers in this assay, from the lowest: compounds 2, 3, 1 and 4 (each within the scatter of the next).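

In this assay, the amide-type nitrogen now has a measured step of its own: methyl in place of hydrogen gives a 1.3-fold higher number from compound 2 to compound 4 (0.12 log units; within the scatter) and so stays within the scatter, which shows that this single added carbon leaves the half-life unresolved from that of the parent amide. The step to methylcarbamoyl in place of trifluoromethyl on the aromatic carbon reads no change at the digits printed from compound 1 to compound 4 (within the scatter) and, taken with a 1.3-fold lower number from compound 1 to compound 2 (0.12 log units; within the scatter) for carbamoyl, shows two amide groups at this place whose half-lives cannot be told apart from that of the trifluoromethyl compound. Nothing measured here explains why these half-lives stay so close together.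

What the compounds leave open is whether anything on this nitrogen or at this aromatic carbon can carry the half-life beyond the scatter, since every step shown so far lies within it. An ethyl or a longer chain on the amide nitrogen, a dimethylcarbamoyl group, or a carboxylic acid in place of the amide would each test that question, and none of these appears among the compounds shown.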